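Swapping a hexyl chain for a cyclohexyl ring

The source may hold more compounds than are shown below. What is called first, only, known or untested is meant among the compounds shown, and "the series" means these compounds.

Compound 1 `CCCCCCn1cnc2c(Nc3ccc(O)cc3)nc(N[C@H]3CC[C@H](N)CC3)nc21` gives 190 nM in a functional assay on EOL1 cells (Homo sapiens) for inhibition, read by fluorescence, with a stated time of 72 h (a higher number here means a weaker inhibitor of growth, a lower number a stronger inhibitor of growth), the lowest of the two numbers measured; compound 2 `CCCCCCn1cnc2c(Nc3ccc(Cl)cc3)nc(N[C@H]3CC[C@H](N)CC3)nc21` gives 440 nM, and a 2.3-fold higher number from compound 1 to compound 2 (0.36 log units; beyond the scatter) describes that step. Compound 3 `N[C@H]1CC[C@H](Nc2nc(Nc3ccc(O)cc3)c3ncn(C4CCCCC4)c3n2)CC1` differs from compound 1 in one place: cyclohexyl in place of hexyl on an aromatic nitrogen. For the measured compounds named here, the only measured step concerns the chloro in place of hydroxy on an aromatic carbon and does not touch the aromatic nitrogen, so nothing measured speaks directly to this change, and the expectation is a step within the scatter in either direction. Compound 3 is estimated at 160 nM, between 55 nM and 470 nM, an expected 1.2-fold lower number from compound 1 to compound 3 (0.07 log units; within the scatter).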

Compound 3, concentration for 50% growth inhibition: 220 nM
For compound 3 the middle estimate is 1.4-fold (0.14 log units) below the measured one; measured number inside the range.
By their numbers in this assay, from the lowest: compounds 1, 3 and 2 (each within the scatter of the next, the first and the last beyond it).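

In this assay, replacing the hexyl chain on the aromatic nitrogen with a cyclohexyl ring gives a 1.2-fold higher number from compound 1 to compound 3 (0.06 log units; within the scatter) and leaves the two compounds indistinguishable. For the compounds shown here, this is the first measured step at this position, and it shows that the open chain and the ring of the same carbon count read alike here. Still open, on these data alone, is whether a shorter chain such as ethyl, a smaller ring such as cyclopentyl, or a ring carrying an amine would also read alike, and whether chloro in place of hydroxy would give the same step on the cyclohexyl compound. No evidence at hand accounts for this result.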